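This account rests on a few compounds, and the source may have more. Where it says the series, first, only, none or still open, it means among the compounds named here.

Compound 1: `O=C(CCc1ccc(C(F)(F)F)cc1)Nc1ccc2nc(N3CC4CC3CN4)ccc2c1`, 210 nM
Compound 2: `CN(c1ccc2cc(NC(=O)CCc3ccc(C(F)(F)F)cc3)ccc2n1)C1CCCC1`, 2 nM
Compound 3: `CC1CCN(c2ccc3cc(NC(=O)CCc4ccc(C(F)(F)F)cc4)ccc3n2)C1`, 2 nM

All three were tested in an assay on isolated protein for displacement of a labelled ligand from melanin-concentrating hormone receptor 1 (Homo sapiens); on this read-out lower numbers stand for stronger inhibition and higher numbers for weaker inhibition. Compound 3 stands level with compound 2 at the digits shown, and the two together give the lowest numbers of the three; the step of no change at the digits printed from compound 2 to compound 3 (within the scatter) lies within the scatter. Compound 1 sits far apart: the steps of a 110-fold lower number from compound 1 to compound 2 (2.02 log units; beyond the scatter) and a 110-fold lower number from compound 1 to compound 3 (2.02 log units; beyond the scatter) were both large and well beyond the scatter, showing that the group on the shared core at that position can matter a great deal.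

Compound 4, `O=C(CCc1ccc(C(F)(F)F)cc1)Nc1ccc2nc(N3CCC(c4ccccc4)C3)ccc2c1`, differs from compound 3 in one place: phenyl in place of methyl on a saturated ring carbon. For the measured compounds named here, no measured step in this set involves a phenyl at this position, so none bears on it directly. Going by the values given here, the only steps available show that a small amine-bearing group there can be exchanged for another without change, while a different kind of group costs a lot.

The step of a 2.5-fold higher number from compound 3 to compound 4 (0.40 log units; beyond the scatter) is therefore an expectation only, and is set small because the step of no change at the digits printed from compound 2 to compound 3 (within the scatter) between two related groups was flat. Compound 4 is expected to give about 5 nM in this assay, with a range from 1 nM to 30 nM.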

Compound 4, half-maximal inhibitory concentration: 25 nM
Compound 4: the middle estimate sits 5.0-fold (0.70 log units) below what was measured; measured number inside the range.
By their numbers in this assay, from the lowest: compounds 2 and 3 (each within the scatter of the next); then compound 4; then compound 1.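

In this assay, for the compounds shown here, the earlier compounds showed only that two quite different amine groups on the aromatic carbon could give the same number, and they said nothing about changes on the pyrrolidine ring itself. The step of a 13-fold higher number from compound 3 to compound 4 (1.10 log units; beyond the scatter) now shows that the saturated ring carbon two ring bonds from the ring nitrogen is sensitive to what it carries, and that phenyl in place of methyl there has a large cost. Set against the other groups on the aromatic carbon, 3-phenylpyrrolidin-1-yl shows a 13-fold higher number from compound 2 to compound 4 (1.10 log units; beyond the scatter) when it replaces cyclopentyl(methyl)amino, but an 8.4-fold lower number from compound 1 to compound 4 (0.92 log units; beyond the scatter) when it replaces the group with two five-membered rings, which places it between them; no measurement here accounts for the cost of the phenyl.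

Still open, going by these compounds, is what happens on this ring carbon with groups that lie between methyl and phenyl, such as ethyl or cyclopropyl. Also open, on these data alone, is whether a hydroxyl, an amine or a benzyl group at the same place would track compound 3 or compound 4.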